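The compounds below may be only part of what the source reports. "The series", "measured", "known", "first", "only" and "open" are said of these compounds alone.

Compound 1, `CCN(c1nc(C)nc(N(CC2CC2)CC2CC2)n1)c1ccc(N(C)C)cc1C(F)(F)F`, gives 5 nM in an assay on isolated protein for binding affinity to corticotropin-releasing factor receptor 1 (Homo sapiens); on this read-out lower numbers stand for stronger inhibition and higher numbers for weaker inhibition.
Compound 2, `CCCCN(CC)c1cc(C)nc(N(CC)c2ccc(I)cc2Br)n1`, gives 14 nM in this assay.
Compound 3, `CCN(CC)c1cc(C)nc(N(CC)c2ccc(N(C)C)cc2Br)n1`, gives 27 nM in this assay.

Among the three measured compounds, compound 1 stands lowest in this assay. Compound 2 comes nearest to it, at a number beyond the scatter above it, and compound 3 lies furthest, also beyond the scatter. Compound 1 is therefore the strongest binder of the set as the numbers stand.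

Compound 4, `CCCN(CCC)c1nc(C)nc(N(CC)c2ccc(N(C)C)cc2C(F)(F)F)n1`, has not yet been measured. It differs from compound 1 in one place: dipropylamino in place of bis(cyclopropylmethyl)amino on an aromatic carbon. The rest of the molecule, including the dimethylamino and trifluoromethyl substituents on the pendant aryl group and the ethyl on the bridging nitrogen, is kept.

Among the measured compounds shown here, no measured pair shows this change directly, so the size of the step can only be guessed. The change is expected to cost a little in this assay, a step from compound 1 to compound 4 of a 2.0-fold higher number from compound 1 to compound 4 (0.30 log units; within the scatter), toward a higher number, though one that may fall within the scatter. Compound 4 is thus estimated at 10 nM, with a range from 3 nM to 35 nM.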

Compound 4, inhibition constant: 6 nM
Compound 4: the middle estimate sits 1.7-fold (0.22 log units) above what was measured; measured number inside the range.
By their numbers in this assay, from the lowest: compounds 1 and 4 (each within the scatter of the next); then compounds 2 and 3 (each within the scatter of the next).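

Replacing bis(cyclopropylmethyl)amino with dipropylamino on this aromatic carbon gives a 1.2-fold higher number from compound 1 to compound 4 (0.08 log units; within the scatter) in this assay, so the two groups cannot be told apart here. Among the compounds shown here, this is the first direct reading at this position, and it shows that, with the rest of compound 1 kept, the two three-membered rings can give way to open propyl chains without a change beyond the scatter. No supporting measurement bears on why the two groups read alike.

From the compounds shown here alone, how far this tolerance extends at the position remains open, since both groups are dialkylamino groups with all-carbon substituents. A ring amine such as morpholine, or a chain carrying an ether oxygen such as bis(2-methoxyethyl)amino, could show whether the same holds for a different kind of group.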